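A few compounds are considered here, and "the series" means these few. Any claim that something is new, unique, unknown or untested is made for them only; others in the source may bear on it.

Measured compounds in an assay for inhibition of serine/threonine-protein kinase Sgk1 (Homo sapiens), with stated times of 30 min and 60 min, in the presence of a further agent that is not named here; on this read-out higher numbers stand for weaker inhibition and lower numbers for stronger inhibition:
compound 1, `Cc1n[nH]c2nc(-c3ccc(NS(=O)(=O)c4cc(Cl)ccc4F)cc3)nc(OCC(CO)CO)c12`, gives 2 nM
compound 2, `Cc1n[nH]c2nc(-c3ccc(NS(=O)(=O)c4cc(Cl)ccc4F)cc3)nc(OCC3CN(C(C)C)C3)c12`, gives 1 nM

Compound 2 stands level with compound 1 in this assay: the step of a 2.0-fold lower number from compound 1 to compound 2 (0.30 log units; within the scatter) lies within the scatter, so the two numbers cannot be told apart. Compound 3, `Cc1n[nH]c2nc(-c3ccc(NS(=O)(=O)c4cc(Cl)ccc4F)cc3)nc(OC3CC(C)(C)NC(C)(C)C3)c12`, carries 2,2,6,6-tetramethylpiperidin-4-yl in place of (1-isopropylazetidin-3-yl)methyl on an oxygen on an aromatic ring. Going by the values given here, no measured step bears directly on this exchange. The only step shown, from compound 1 to compound 2, also replaces the group on the saturated chain carbon bound to the aromatic oxygen, and that replacement moved the number by no more than the scatter; it is the sole guide here. On that basis compound 3 is expected to sit near compound 2, with an estimated step of a 2.0-fold higher number from compound 2 to compound 3 (0.30 log units; within the scatter) that is unlikely to exceed the scatter by much. The estimate for compound 3 in this assay is 2 nM, with a range from 0.5 nM to 10 nM.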

Compound 3, half-maximal inhibitory concentration: 4 nM
Compound 3: the middle estimate sits 2.0-fold (0.30 log units) below what was measured, and the stated range covers the measured number.
By their numbers in this assay, from the lowest: compounds 2, 1 and 3 (each within the scatter of the next, the first and the last beyond it).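

In this assay, going by these compounds alone, 2,2,6,6-tetramethylpiperidin-4-yl in place of (1-isopropylazetidin-3-yl)methyl on the oxygen on an aromatic ring gives a 4.0-fold higher number from compound 2 to compound 3 (0.60 log units; beyond the scatter), the first step at this position that lies beyond the scatter, though it is a modest one. Set against the 3-hydroxy-2-(hydroxymethyl)propyl group, the same entering group gives a 2.0-fold higher number from compound 1 to compound 3 (0.30 log units; within the scatter), so the position takes a six-membered ring attached directly to the oxygen with no difference that can be told from that group. Nothing at hand explains the step from the azetidine group to the piperidine group.

The compounds shown leave open how a plain piperidin-4-yl, without the methyl groups, would read on this oxygen, which would help separate the ring from its substituents. From the compounds shown here alone, how a carboxylic acid or a longer chain would read here also stays open.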